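Compound 2 to compound 4: a trifluoromethoxy swap

This account rests on a few compounds, and the source may have more. Where it says the series, first, only, none or still open, it means among the compounds named here.

Measured so far in an ADME assay on Vero cells (Chlorocebus sabaeus) for cytotoxicity, read by resazurin assay, with a stated time of 72 h; on this read-out lower numbers stand for stronger inhibition and higher numbers for weaker inhibition:
compound 1 `O=C(CCN1CCN(c2ccc(C(F)(F)F)cc2)CC1)c1ccc(C(F)(F)F)cc1` gives 49200 nM
compound 2 `O=C(CCN1CCN(c2ccc(Cl)cc2)CC1)c1ccc(C(F)(F)F)cc1` gives 54200 nM
compound 3 `O=C(CCN1CCN(c2ccc([N+](=O)[O-])cc2)CC1)c1ccc(C(F)(F)F)cc1` gives 75700 nM

The three values form one group, and compound 2, at 54200 nM, is not separated from either of the others. Its nearest step is a 1.1-fold higher number from compound 1 to compound 2 (0.04 log units; within the scatter), and the other step that touches it is a 1.4-fold higher number from compound 2 to compound 3 (0.15 log units; within the scatter). The remaining step is a 1.5-fold higher number from compound 1 to compound 3 (0.19 log units; within the scatter).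

Compound 4 `O=C(CCN1CCN(c2ccc(Cl)cc2)CC1)c1ccc(OC(F)(F)F)cc1` is still unmeasured. It differs from compound 2 by one change: trifluoromethoxy in place of trifluoromethyl on an aromatic carbon. In words, this is trifluoromethoxy in place of trifluoromethyl on an aromatic carbon.

Among the measured compounds shown here, no measured step makes this exact change, and none alters the group that leaves here. For the measured compounds named here, the only guide is indirect: the three steps above all replace a different substituent, and each stays within the scatter. With so few compounds, this is weak support, and it says nothing about trifluoromethoxy itself. No direction can be drawn from these data, so no step beyond the scatter is expected in this assay.

The estimated step is a 1.0-fold lower number from compound 2 to compound 4 (0.02 log units; within the scatter).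

For compound 4 the expected value is 52000 nM, with an estimated range from 30000 nM to 90000 nM.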

Compound 4, half-maximal inhibitory concentration: 95600 nM
The estimate for compound 4 lay 1.8-fold (0.26 log units) below the measured number; measured number outside the range, above it.
By their numbers in this assay, from the lowest: compounds 1, 2, 3 and 4 (each within the scatter of the next).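

In this assay, the step at this place reads a 1.8-fold higher number from compound 2 to compound 4 (0.25 log units; within the scatter), the first in the series to touch the trifluoromethyl group that compound 1, compound 2 and compound 3 all carry on the aromatic carbon para to a large group. The earlier steps shown here changed only the substituent at the other end of the shared core, so they said nothing about this place; this step shows that here too, a change from trifluoromethyl to trifluoromethoxy, which brings in an oxygen and a hydrogen-bond acceptor, stays within the scatter, and all four compounds remain one group. Nothing available accounts for the size of this step.

A single replacement cannot show whether this place tolerates change in general, and an amine, a carboxylic acid or a longer chain in place of trifluoromethyl could still give a step beyond the scatter. Also open, on these data alone, is whether trifluoromethoxy gives a similar step when the chloro of compound 2 is replaced by the nitro of compound 3 or the trifluoromethyl of compound 1.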